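The source may report more compounds than this note shows. Statements on the series, on what has been measured and on what is new or still open speak of the compounds shown alone.

Measured in a functional assay on MCF7 cells (Homo sapiens) for inhibition, read by CCK-8 assay, with a stated time of 72 h; a higher number here means a weaker inhibitor, a lower number a stronger inhibitor:
- compound 1 `Cc1ccc(NS(=O)(=O)c2cccc(CCCCCCNC(=O)/C=C/c3cccnc3)c2)cc1`: 1.97 nM
- compound 2 `Cc1ccccc1NS(=O)(=O)c1cccc(CCCCCCNC(=O)/C=C/c2cccnc2)c1`: 0.226 nM
- compound 3 `CCc1ccc(NS(=O)(=O)c2cccc(CCCCCCNC(=O)/C=C/c3cccnc3)c2)cc1`: 3.64 nM

Compound 3 shares the weak end of this small set with compound 1, as shown by a 1.8-fold higher number from compound 1 to compound 3 (0.27 log units; within the scatter). Compound 2 stands well apart, with a 16-fold higher number from compound 2 to compound 3 (1.21 log units; beyond the scatter).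

The next analogue is compound 4 `CC(C)(C)c1ccc(NS(=O)(=O)c2cccc(CCCCCCNC(=O)/C=C/c3cccnc3)c2)cc1`, with the change tert-butyl in place of ethyl on an aromatic carbon, para to a large group.

Within the data shown here, the closest precedent is a 1.8-fold higher number from compound 1 to compound 3 (0.27 log units; within the scatter), the only measured step that enlarges this alkyl group. The larger steps, an 8.7-fold lower number from compound 1 to compound 2 (0.94 log units; beyond the scatter) and a 16-fold higher number from compound 2 to compound 3 (1.21 log units; beyond the scatter), both involve the 2-methylphenyl group of compound 2, which compound 4 lacks, so they bear on it only weakly. Among the measured compounds shown here, no measured compound carries tert-butyl, so the expectation rests on a single step.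

The expected step is small and upward, a 1.4-fold higher number from compound 3 to compound 4 (0.14 log units; within the scatter), and is not expected to exceed the scatter.

For compound 4 the estimated value is 5 nM, with an expected range of 1.5 nM to 16 nM.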

Compound 4, half-maximal inhibitory concentration: 26.3 nM
The estimate for compound 4 lay 5.3-fold (0.72 log units) below the measured number; measured number above the stated range.
By their numbers in this assay, from the lowest: compound 2; then compounds 1 and 3 (each within the scatter of the next); then compound 4.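

In this assay, among these compounds, tert-butyl in place of ethyl on this aromatic carbon, para to a large group, gives a 7.2-fold higher number from compound 3 to compound 4 (0.86 log units; beyond the scatter), the first step beyond the scatter among the alkyl groups at this place; methyl to ethyl gave only a 1.8-fold higher number from compound 1 to compound 3 (0.27 log units; within the scatter). The response to added carbon here is therefore uneven: the 4-(tert-butyl)phenyl compound also stands clear of the methyl analogue, with a 13-fold higher number from compound 1 to compound 4 (1.13 log units; beyond the scatter), and the gap to the 2-methylphenyl compound reaches a 120-fold higher number from compound 2 to compound 4 (2.07 log units; beyond the scatter). No measurement available here accounts for the rise with tert-butyl.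

Going by these compounds, whether the rise follows the carbon count or the branching of tert-butyl remains open, and isopropyl and n-butyl in the same place would separate the two. How an amine or a carboxylic acid would fare at this carbon is also unresolved.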